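Ethyl to methyl on a chain: tolerance still unread

This account rests on a few compounds, and the source may have more. Where it says the series, first, only, none or still open, it means among the compounds named here.

Compound 1 `CCCCc1ccc(-c2ccc3ncc(-c4noc(C)n4)cc3c2)cc1`: in a functional assay on RD cells (Homo sapiens) for inhibition, read by luminescence and ATP content, with a stated time of 72 h (a higher number here means that more compound is tolerated, a lower number that less compound is tolerated), compound 1 gives > 2500 nM, which is a limit of the measurement and not a number.
Compound 2 `CCCCc1ccc(-c2ccc3ncc(-c4noc(CC)n4)cc3c2)cc1`: in this assay compound 2 gives > 7400 nM, again only a limit.
Compound 3 `CCc1ccc(-c2ccc3ncc(-c4noc(CC)n4)cc3c2)cc1`: in this assay compound 3 gives > 22200 nM, also a limit.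

All three measured compounds share one core and differ only in two short chains. From compound 2 to compound 1 the change is hydrogen in place of methyl on a saturated chain carbon bound to an aromatic carbon, and the resulting step is a step that the two limits leave unreadable from compound 2 to compound 1; it stays unreadable because the limit of > 7400 nM in this assay, at which 1 of the 3 values shown sits, and the limit of > 2500 nM in this assay, at which 1 of the 3 values shown sits, are both limits. From compound 2 to compound 3 the cores differ by hydrogen in place of ethyl on a saturated chain carbon, two bonds along the chain from an aromatic carbon, and the step is a step that the two limits leave unreadable from compound 2 to compound 3, likewise unreadable because the limit of > 7400 nM in this assay, at which 1 of the 3 values shown sits, and the limit of > 22200 nM in this assay, at which 1 of the 3 values shown sits, are limits.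

Compound 4 `CCc1nc(-c2cnc3ccc(-c4ccc(C)cc4)cc3c2)no1` has not been measured. It differs from compound 3 by hydrogen in place of methyl on a saturated chain carbon bound to an aromatic carbon, the same change as from compound 2 to compound 1, so this change occurs twice among the compounds shown. Read one bond further out, the new pair is 4-ethylphenyl to 4-methylphenyl, whereas the earlier pair is 5-ethyl-1,2,4-oxadiazol-3-yl to 5-methyl-1,2,4-oxadiazol-3-yl.

Since the earlier instance of this change gave no readable step, and every measured value here is a limit, the step expected from compound 3 to compound 4 in this assay is a step that the limit leaves unreadable from compound 3 to compound 4, essentially no change, resting on compound 3 at > 22200 nM being a limit. Compound 4 is therefore estimated at 30000 nM, with a range from 10000 nM to 100000 nM, and most likely it too will be reported only as a limit.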

Compound 4, half-maximal cytotoxic concentration: > 7400 nM
Compound 4: only a limit was reported; the forecaster's own chance of this, stated with the estimate: 80%; the middle value is on the limit's open side.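

No size can be read for the step from compound 3 to compound 4, or for the step from compound 2 to compound 4: in this assay all three compounds are reported only as limits. The compounds shown leave open what concentration of any of them the cells fail to tolerate, and whether shortening either chain changes that tolerance at all.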